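The compounds below may be only part of what the source reports. "The series", "measured", "known", "first", "only" and "open" are said of these compounds alone.

Measured so far:
- compound 1, `COc1cc(O)c(C(=O)/C=C/c2ccc(F)cc2)c(OC)c1`: "not active" (no number reported)
- compound 2, `COc1cc(OC)c(C(=O)/C=C/c2ccccc2SC)c(OC)c1`: 37%

Going by the values given here, in a functional assay on Huh-7 cells (Homo sapiens), read by fluorescence and BrdU incorporation, with a stated time of 48 h, tested at 10 uM (a higher number here means a weaker effect of the compound at the concentration tested, a lower number a stronger effect), compound 2 gives 37%, the only number; compound 1 is reported there as "not active" (no number reported) without a figure. Compound 3, `COc1cccc(/C=C/C(=O)c2c(OC)cc(OC)cc2OC)c1`, is not yet measured. It differs from compound 2 as follows: 3-methoxyphenyl in place of 2-(methylsulfanyl)phenyl on a double-bonded chain carbon bound to a double-bonded chain carbon. Among the compounds with values here, no measured pair shows this kind of exchange, so its effect is open; a step from compound 2 to compound 3 of modest size toward a higher number in this assay is expected, but one within the scatter is also plausible. For compound 3 the expected value is 52%, range 28% to 85%, an expected step of a number 15 percentage points higher from compound 2 to compound 3 (beyond the scatter).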

Compound 3, a percentage reported as activity, at one concentration (the size of the read-out at that concentration, not a potency): 40%
Compound 3: the middle estimate sits 12 percentage points above what was measured; low and high end bracket the measured number.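

In this assay, 3-methoxyphenyl in place of 2-(methylsulfanyl)phenyl on a double-bonded chain carbon bound to a double-bonded chain carbon gives a number 3 percentage points higher from compound 2 to compound 3 (within the scatter). Going by these compounds alone, this is the first comparison at this place, and the read-out does not separate these two groups. No measured property bears on this result.

Compound 1 differs from both in more than one place, so it does not help with this exchange. Still open, going by these compounds, is whether an amine or a carboxylic acid on the phenyl ring at this place would read like these two groups.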